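Chloro to Bromo: Expected Effect on Cell Growth Inhibition

The source may hold more compounds than are shown below. What is called first, only, known or untested is meant among the compounds shown, and "the series" means these compounds.

Measured compounds:
Compound 1 `O=C1C(=O)N(CN2CCN(c3ccnc4cc(C(F)(F)F)ccc34)CC2)c2cccc(Cl)c21` — 28400 nM
Compound 2 `O=C1C(=O)N(CN2CCN(c3ccnc4cc(C(F)(F)F)ccc34)CC2)c2cc(Br)ccc21` — 24800 nM
Compound 3 `NC(=S)N/N=C1/C(=O)N(CN2CCN(c3ccnc4cc(Cl)ccc34)CC2)c2cccc(Cl)c21` — 57600 nM

In a functional assay on MDA-MB-468 cells (Homo sapiens) for cytotoxicity, read by sulforhodamine B assay, with a stated time of 48 h (on this read-out lower numbers stand for stronger inhibition of growth and higher numbers for weaker inhibition of growth), compound 1 gives 28400 nM and compound 2 gives 24800 nM. Compound 3 gives 57600 nM in this assay, which is the highest of the three numbers; its gap to compound 1 and its gap to compound 2 both lie beyond the usual scatter, so compound 3 is the weakest growth inhibitor among those measured. Compound 3 differs from the other two in more than one part of the structure, so no single change can be read from those comparisons.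

Compound 4 `NC(=S)N/N=C1/C(=O)N(CN2CCN(c3ccnc4cc(Cl)ccc34)CC2)c2cccc(Br)c21` is not yet measured. It differs from compound 3 only by bromo in place of chloro on an aromatic carbon. Among the compounds with values here, no measured pair shows this exact change, so there is no direct guide. A change of one halogen for another at the same carbon is expected to move this assay little, with no clear direction and most likely no shift beyond the scatter. The expected step of a 1.1-fold lower number from compound 3 to compound 4 (0.04 log units; within the scatter) is therefore small. Compound 4 is estimated at 52000 nM, with a range from 25000 nM to 110000 nM.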

Compound 4, concentration for 50% growth inhibition: 40400 nM
Compound 4: middle estimate off by 1.3-fold (0.11 log units), on the high side; measured number inside the range.
By their numbers in this assay, from the lowest: compounds 2, 1, 4 and 3 (each within the scatter of the next, the first and the last beyond it).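

Within the data shown here, compound 3 and compound 4 form the first pair here that differs in one place, so they give the first direct reading of a single change. In this assay, bromo in place of chloro on this aromatic carbon gives a 1.4-fold lower number from compound 3 to compound 4 (0.15 log units; within the scatter) and so leaves the two compounds indistinguishable, which means this swap of one halogen for the other does not separate them on this read-out. Nothing measured here bears on why that is so.

The compounds shown leave open whether a group other than a halogen on this same carbon, such as an amine, a methoxy group or a carboxylic acid, would move the number beyond the scatter. They also leave open whether bromo in place of chloro would act the same way on the core of compound 1.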